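The source may report more compounds than this note shows. Statements on the series, on what has been measured and on what is new or still open speak of the compounds shown alone.

Measured in a functional assay on the whole organism for inhibition, with Rattus norvegicus as the target; a higher number here means that more compound is needed for the effect, a lower number that less compound is needed:

compound 1 `CC1C/C(=N\Nc2ccccc2)c2ncc(C(=O)O)c(=O)n2C1` — > 320 umol/kg
compound 2 `CC1CCn2c(ncc(C(=O)O)c2=O)/C1=N/Nc1ccccc1` — > 320 umol/kg
compound 3 `CC1CC/C(=N\Nc2ccccc2Cl)c2ncc(C(=O)O)c(=O)n21` — > 1000 umol/kg

All three values are limits of the assay, not numbers. Compound 3 gives only a limit, > 1000 umol/kg, in this assay. Compound 1 likewise gives only a limit, > 320 umol/kg. Compound 2 also gives only a limit, > 320 umol/kg. Compound 3 thus sits at the limit of > 1000 umol/kg in this assay, at which 1 of the 3 values shown sits, while the other two values sit at the limit of > 320 umol/kg in this assay, at which 2 of the 3 values shown sit; none of the three allows a measured step to be read, and nothing can be said of order among them.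

Compound 4 `Cc1ccccc1N/N=C1\CCC(C)n2c1ncc(C(=O)O)c2=O` differs from compound 3 in one place: methyl in place of chloro on an aromatic carbon. For the measured compounds named here, with no measured step to draw on, the expectation for this change is no movement beyond the usual scatter, and most likely a further limit rather than a number. The step of a number no higher from compound 3 to compound 4 (the limit leaves the size open) is expected to stay within that scatter. For compound 4 the estimated dose in this assay is 1000 umol/kg, with a range from 320 umol/kg to 3000 umol/kg.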

Compound 4, dose for 50% inhibition: > 100 umol/kg
Compound 4: a limit, no number; the forecaster's own chance of this, stated with the estimate: 85%; the middle value lies beyond the limit too.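

Compound 3 and compound 4 both give only limits of the assay, not numbers, so no step can be read between them. The compounds shown leave open whether methyl in place of chloro changes the dose needed, and what dose any of these compounds requires.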